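A few compounds are considered here, and "the series" means these few. Any claim that something is new, unique, unknown or untested is made for them only; others in the source may bear on it.

Among the measured compounds shown here, compound 3 `CC(C)C[C@H](N)c1cc(C(F)(F)F)ccc1N1CCN(C(=O)CC(C)C(=O)c2ccc(Cl)cc2)CC1` gives 1100 nM in an assay on HEK293 cells for displacement of a labelled ligand from Melanocortin receptor 4 (Homo sapiens); on this read-out lower numbers stand for stronger inhibition and higher numbers for weaker inhibition; it and compound 1 `CC(C)C[C@H](N)c1cc(C(F)(F)F)ccc1N1CCN(C(=O)COc2ccc3ccccc3c2)CC1`, at 2000 nM, sit within the scatter of each other and are the only plain numbers in the set. Compound 2 `CC(C)C[C@H](N)c1cc(C(F)(F)F)ccc1N1CCN(C(=O)CCC(N)=O)CC1` reaches only the limit of this assay, > 10000 nM. Compound 4 `CC(C)C[C@H](N)c1cc(C(F)(F)F)ccc1N1CCN(C(=O)COc2cccc(Cl)c2Cl)CC1` differs from compound 3 by 2,3-dichlorophenoxy in place of 1-((4-chlorophenyl)carbonyl)ethyl on a saturated chain carbon bound to a carbonyl carbon. The step bearing most directly on this runs the other way, a 1.8-fold lower number from compound 1 to compound 3 (0.26 log units; within the scatter), an aryl ether against the ketone chain. Dropping the aryl ring altogether cost more: an at least 5.0-fold higher number from compound 1 to compound 2 (0.69 log units; beyond the scatter) and an at least 9.0-fold lower number from compound 2 to compound 3 (0.95 log units; beyond the scatter). Since compound 4 keeps an aryl ether, the step of a 1.5-fold higher number from compound 3 to compound 4 (0.16 log units; within the scatter) is expected to be small. The estimate for compound 4 is 1600 nM, in the range 500 nM to 6000 nM.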

Compound 4, inhibition constant: 2500 nM
For compound 4 the middle estimate is 1.6-fold (0.19 log units) below the measured one; the range from low to high includes it.
By their numbers in this assay, from the lowest: compounds 3, 1 and 4 (each within the scatter of the next, the first and the last beyond it). At a limit, above all of these: compound 2.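

With the aryl ether kept, exchanging the group on oxygen registers little, a 1.3-fold higher number from compound 1 to compound 4 (0.10 log units; within the scatter), so 2,3-dichlorophenyl and naphthalen-2-yl are not told apart here. The ketone chain now separates from an aryl ether, though only modestly, a 2.3-fold higher number from compound 3 to compound 4 (0.36 log units; beyond the scatter). A second aryl ether also stands clear of the carbamoylmethyl chain, an at least 4.0-fold lower number from compound 2 to compound 4 (0.60 log units; beyond the scatter), but this step rests on a limit rather than a number, and compound 2 is the compound at that limit: the limit of > 10000 nM in this assay, at which 1 of the 4 values shown sits.

Open, as far as these compounds go, is whether a longer chain between the carbonyl and the aryl ether would change the binding number. Also open, from the compounds shown here alone, is how a carboxylic acid or an amine at this place would compare.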